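Bromo added beside trifluoromethyl on the ether ring

A few compounds are considered here, and "the series" means these few. Any claim that something is new, unique, unknown or untested is made for them only; others in the source may bear on it.

Three compounds of this series have numbers in an assay on HEK293 cells for inhibition of Toll-like receptor 8 (Homo sapiens), with a stated time of 16 h; a lower number here means a stronger inhibitor, a higher number a weaker inhibitor. Compound 1 `O=C(Nc1ccc(Oc2cc(C(F)(F)F)cc(C(F)(F)F)c2)cc1)c1c(F)cccc1Br` gives 6000 nM. Compound 2 `O=C(Nc1ccc(Oc2cc(C(F)(F)F)cc(C(F)(F)F)c2)cc1O)c1c(F)cccc1Cl` gives 4020 nM. Compound 3 `O=C(Nc1ccc(Oc2cccc(C(F)(F)F)c2)cc1)c1c(F)cccc1Cl` gives 2410 nM, the lowest of the three numbers; its gap to compound 2 lies within the scatter, so nothing separates those two, while compound 1 stands beyond the scatter with the higher number. Among the measured compounds shown here, compound 1 differs from compound 3 in more than one place, so that pair shows only its two values and no single step.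

Compound 4 `O=C(Nc1ccc(Oc2cc(Br)cc(C(F)(F)F)c2)cc1)c1c(F)cccc1Cl` is the next candidate. Relative to compound 3 it carries bromo in place of hydrogen on an aromatic carbon. For the measured compounds named here, no measured pair in this set makes exactly this change. Going by the values given here, the only pointer is compound 1, which carries a second trifluoromethyl on that ring and differs elsewhere too, and which gives the highest number here, 6000 nM.

On that basis a small upward step is expected, a 1.5-fold higher number from compound 3 to compound 4 (0.16 log units; within the scatter), one that may well stay within the scatter. Compound 4 is therefore estimated at 3500 nM in this assay, with a plausible range from 1500 nM to 8000 nM.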

Compound 4, half-maximal inhibitory concentration: 2320 nM
Compound 4: middle estimate off by 1.5-fold (0.18 log units), on the high side; the measured number falls inside the stated range.
By their numbers in this assay, from the lowest: compounds 4, 3, 2 and 1 (each within the scatter of the next, the first and the last beyond it).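

In this assay, bromo in place of hydrogen on an aromatic carbon, meta to a trifluoromethyl group, gives a 1.0-fold lower number from compound 3 to compound 4 (0.02 log units; within the scatter), so this position accepts the added bromine atom with no readable shift in the number. The earlier compounds shown here could not show this: compound 1 also carries a further group on that carbon, but it differs from compound 3 in more than one place, and its higher number could not be tied to that position. Compound 4 now shows that filling this carbon with bromo does not by itself raise the number, and no measurement on hand bears on why the number holds steady here.

Going by these compounds, whether other groups on this carbon, such as an amine, a carboxylic acid or a longer chain, would also leave the number unmoved remains open. Among the compounds shown here, also open is how trifluoromethyl in place of bromo would read with the rest of compound 4 unchanged, since compound 1 differs from compound 4 in more than one place and gives no single step.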